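Isobutoxy for Acetamido on the Core of Compound 1

The source may hold more compounds than are shown below. What is called first, only, known or untested is meant among the compounds shown, and "the series" means these compounds.

Compound 1 `CC(=O)Nc1cccc(-c2ccc(C(=O)N(Cc3cccc(OCCCCCC(=O)O)c3)C(C)C)cc2)c1` was measured in an ADME assay on Raji cells (Homo sapiens) for cytotoxicity, read by CellTiter-Glo and resazurin assay, with a stated time of 72 h; on this read-out lower numbers stand for an effect already at smaller amounts and higher numbers for an effect only at larger amounts of compound. In this assay compound 1 gives > 26000 nM, which is a limit of the assay and not a number. A related compound 2 `CC(C)N(Cc1cccc(OCCCCCC(=O)O)c1)C(=O)c1ccc(-c2cccc(-c3ccccc3)c2)cc1` carries a phenyl in place of the acetamido on an aromatic carbon. In this assay compound 2 gives > 26000 nM, likewise a limit. The step that the two limits leave unreadable from compound 1 to compound 2 is therefore of unknown size, as the limit of > 26000 nM in this assay, at which 2 of the 2 values shown sit, shows. Compound 3 `CC(C)COc1cccc(-c2ccc(C(=O)N(Cc3cccc(OCCCCCC(=O)O)c3)C(C)C)cc2)c1` has not yet been measured. It differs from compound 1 by isobutoxy in place of acetamido on an aromatic carbon. Within the data shown here, the only measured step that bears on this place is the unreadable one, so no direction can be drawn from it, and the data give no number for compound 1 itself to start from. Compound 3 is accordingly expected to show no effect within the range of this assay as well. The expected step is a step that the limit leaves unreadable from compound 1 to compound 3, none beyond the scatter. The estimate for compound 3 is 35000 nM, within a range from 15000 nM to 90000 nM.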

Compound 3, half-maximal effective concentration: > 26000 nM
Compound 3 ended at the assay's limit; the forecaster's own chance of this, stated with the estimate: 80%; the middle value does not contradict the limit.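

No step can be read among compound 1, compound 2 and compound 3 in this assay as each value is a limit and not a number: the limit of > 26000 nM in this assay, at which 3 of the 3 values shown sit.

The compounds shown leave open whether any change at this aromatic carbon moves the value, and where any of the three actually stands.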